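Pyridine Isomer Swap on the Alkyne of Compound 1

The source may hold more compounds than are shown below. What is called first, only, known or untested is meant among the compounds shown, and "the series" means these compounds.

Measured so far:
compound 1 `Cc1ccc(-n2nccn2)c(C(=O)N2C[C@H](C#Cc3cncc(CO)c3)CC[C@H]2C)c1` gives 32 nM in an assay on cells for binding affinity to Orexin receptor type 2 (Homo sapiens), read by radioligand binding; a lower number here means a stronger inhibitor, a higher number a weaker inhibitor
compound 2 `Cc1ccc(-n2nccn2)c(C(=O)N2C[C@H](C#Cc3cnccc3O)CC[C@H]2C)c1` gives 7.5 nM in this assay
compound 3 `Cc1ccc(-n2nccn2)c(C(=O)N2C[C@H](C#Cc3cc(CO)ccn3)CC[C@H]2C)c1` is not yet measured in this assay

Compound 1 holds the highest of the two numbers; its nearest neighbour is compound 2, reached by a 4.3-fold lower number from compound 1 to compound 2 (0.63 log units; beyond the scatter), a modest gain on replacing the 5-(hydroxymethyl)pyridin-3-yl group.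

Compound 3 differs from compound 1 by 4-(hydroxymethyl)pyridin-2-yl in place of 5-(hydroxymethyl)pyridin-3-yl on a triple-bonded carbon. The same atoms are kept and only rejoined, so the hydroxymethyl and the ring nitrogen shift together on the ring attached to the triple-bonded carbon.

Within the data shown here, only one step bears on this: the step from compound 1 to compound 2, which also altered the pyridyl on the triple-bonded carbon and was of modest size. That step swapped the hydroxymethyl for a ring hydroxyl, a different kind of change, so it does not test the present rearrangement directly. The ring attached at that position tolerates alteration, and a small step at most is expected for compound 3, a 1.1-fold lower number from compound 1 to compound 3 (0.03 log units; within the scatter), within the scatter. Compound 3 is therefore estimated at 30 nM, with a range from 10 nM to 90 nM.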

Compound 3, inhibition constant: 42 nM
Compound 3: middle estimate off by 1.4-fold (0.15 log units), on the low side, within the range that was stated.
By their numbers in this assay, from the lowest: compound 2; then compounds 1 and 3 (each within the scatter of the next).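

In this assay, rejoining the same atoms as 4-(hydroxymethyl)pyridin-2-yl in place of 5-(hydroxymethyl)pyridin-3-yl on a triple-bonded carbon gives a 1.3-fold higher number from compound 1 to compound 3 (0.12 log units; within the scatter) and so does not separate these two hydroxymethyl isomers, which shows that this position accepts a joint shift of the hydroxymethyl and the ring nitrogen without a resolved change. The other comparison gives a 5.6-fold higher number from compound 2 to compound 3 (0.75 log units; beyond the scatter) and places compound 2 apart from both hydroxymethyl isomers, so among these three compounds the lower number goes with 4-hydroxypyridin-3-yl and not with where the hydroxymethyl sits. No available measurement bears on the origin of these differences.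

Open is whether the lower number of compound 2 belongs to the ring hydroxyl itself or to its particular arrangement with the ring nitrogen, as the pyridine isomers shown carry only hydroxymethyl or that one hydroxyl arrangement. Also open, from the compounds shown here alone, is how this position responds to an aminomethyl group, a carboxylic acid or a longer 2-hydroxyethyl chain in place of the hydroxymethyl.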